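Three measured compounds, one phenol swap, one estimate

This account rests on a few compounds, and the source may have more. Where it says the series, first, only, none or still open, it means among the compounds named here.

Compound 1 `COc1ccc(C2CC(c3cc4ccccc4o3)=NN2C(=O)c2ccncc2)c(O)c1`: > 190000 nM
Compound 2 `O=C(c1ccncc1)N1N=C(c2cc3ccccc3o2)CC1c1ccc(O)cc1`: > 200000 nM
Compound 3 `CCn1cc(C(=O)N2N=C(c3cc4ccccc4o3)CC2c2ccc(OC)cc2O)c(=O)c2ccc(C)nc21`: > 154000 nM

In an ADME assay on Vero cells (Chlorocebus sabaeus) for cytotoxicity, read by MTT assay, with a stated time of 72 h (a higher number here means a weaker inhibitor, a lower number a stronger inhibitor), compound 1 gives only a limit, > 190000 nM. Compound 2 likewise gives only a limit in this assay, > 200000 nM. Compound 3 also returns a limit in this assay, > 154000 nM. Compound 2 differs from compound 1 by 4-hydroxyphenyl in place of 2-hydroxy-4-methoxyphenyl on a saturated ring carbon. The step that the two limits leave unreadable from compound 1 to compound 2 cannot be sized because the limit of > 190000 nM in this assay, at which 1 of the 3 values shown sits, and the limit of > 200000 nM in this assay, at which 1 of the 3 values shown sits, are both limits, so nothing is known about its direction or size.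

Compound 4 `CCn1cc(C(=O)N2N=C(c3cc4ccccc4o3)CC2c2ccc(O)cc2)c(=O)c2ccc(C)nc21` has not yet been measured; it differs from compound 3 by 4-hydroxyphenyl in place of 2-hydroxy-4-methoxyphenyl on a saturated ring carbon. The difference between the core of compound 1 and the core of compound 3 is not broken down here. The two places are not the same word for word: in the first pair the saturated ring carbon is next to the ring atom that bears a (pyridin-4-yl)carbonyl group (8 heavy atoms), in the second pair it is next to the ring atom that bears a large group. The change is therefore the same kind of change, not the same.

For compound 4 the step that the limit leaves unreadable from compound 3 to compound 4 is expected to stay unreadable, since compound 3 sits at the limit of > 154000 nM in this assay, at which 1 of the 3 values shown sits, and the same kind of change gave compound 2 a limit as well. For compound 4 the value in this assay is estimated at 250000 nM, with a range from 150000 nM to 450000 nM.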

Compound 4, half-maximal inhibitory concentration: > 148000 nM
Compound 4: no number, only a limit (the forecaster's own chance of this, stated with the estimate: 85%); the middle value lies beyond the limit too.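

Compound 3 and compound 4 both return only limits in this assay, so the step between them cannot be read, either in direction or in size. The compounds shown leave open where the half-maximal inhibitory concentration of any of them actually lies, and whether 4-hydroxyphenyl in place of 2-hydroxy-4-methoxyphenyl changes the read-out in this assay at all on either core.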